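The source may hold more compounds than are shown below. What is called first, only, known or untested is meant among the compounds shown, and "the series" means these compounds.

Compound 3 `Cc1ccccc1-c1nn(-c2cc(F)ccc2F)cc1CNCCN1CCN(C)CC1` belongs to a small family of closely related compounds tested in an ADME assay on Huh-7 cells (Homo sapiens) for cytotoxicity; a higher number here means that more compound is tolerated, a lower number that less compound is tolerated. In this assay compound 3 gives > 20000 nM, which is a limit of the assay rather than a number. Among the measured compounds shown here, compound 1 `Cc1ccccc1-c1nn(-c2ccc(Cl)cc2)cc1CNCCN1CCN(C)CC1` is the only member of the family with a numerical result: in this assay compound 1 gives 17000 nM. Compound 2 `COc1ccc(-n2cc(CNCCN3CCN(C)CC3)c(-c3ccccc3C)n2)cc1` in this assay gives > 20000 nM, again a limit. For the measured compounds named here, two measured steps bear on the question: an at least 1.1-fold higher number from compound 1 to compound 2 (0.07 log units; that floor lies within the scatter) and an at least 1.1-fold higher number from compound 1 to compound 3 (0.07 log units; that floor lies within the scatter). The step that the two limits leave unreadable from compound 2 to compound 3 cannot be read, because of the limit of > 20000 nM in this assay, at which 2 of the 3 values shown sit. Compound 4 `Cc1ccccc1-c1nn(-c2ccc(F)c(F)c2)cc1CNCCN1CCN(C)CC1` differs from compound 3 by 3,4-difluorophenyl in place of 2,5-difluorophenyl on an aromatic nitrogen. Since both measured steps starting from compound 1 reach the same limit and their floors lie within the scatter, no step beyond the scatter is expected in this assay, and the expected step is a number no higher from compound 3 to compound 4 (the limit leaves the size open). Compound 4 is therefore estimated to give 20000 nM in this assay, with a range from 10000 nM to 40000 nM, and it is likely that only a limit will again be reported.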

Compound 4, half-maximal cytotoxic concentration: > 20000 nM
Compound 4 gave a limit, no number; the forecaster's own chance of this, stated with the estimate: 70%; the middle value sits exactly at the limit.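

The result for compound 4 in this assay is again a limit of the assay, not a number: > 20000 nM. The earlier compounds shown here showed two different groups on this aromatic nitrogen reaching that limit; compound 4 adds that 3,4-difluorophenyl does so too, with the same atoms as the 2,5-difluorophenyl of compound 3, joined differently. Among the compounds shown here, the only step that can be read is an at least 1.1-fold higher number from compound 1 to compound 4 (0.07 log units; that floor lies within the scatter), so compound 4 cannot be separated from compound 1 in this assay, and the steps from compound 2 and compound 3 to compound 4 cannot be read because of a shared ceiling: the limit of > 20000 nM in this assay, at which 3 of the 4 values shown sit.

On these data alone, with three of the four compounds at the limit, it remains open how far the compounds that sit there differ from one another, and whether 4-chlorophenyl is unusual in giving a number. As far as these compounds go, it is also open whether a phenyl ring carrying a carboxylic acid or an amine, or a longer chain in place of the ring on this nitrogen, would give a number in this assay.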